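This account rests on a few compounds, and the source may have more. Where it says the series, first, only, none or still open, it means among the compounds named here.

Measured in an ADME assay on cells (Fibroblast, Homo sapiens) for antiproliferative activity, read by sulforhodamine B assay, with a stated time of 48 h; a lower number here means a stronger inhibitor, a higher number a weaker inhibitor:
- compound 1 `CCCCCCCCCCCCCCCCNC(=O)[C@@H]1CSC(c2ccc(NC(C)=O)cc2)N1`: 19100 nM
- compound 2 `CCCCCCCCCCCCCCCCCCNC(=O)[C@@H]1CSC(c2ccc(NC(C)=O)cc2)N1`: > 60000 nM (a limit of the assay, not a number)
- compound 3 `CCCCCCCCC/C=C/CCCCCCCNC(=O)[C@@H]1CSC(c2ccc(NC(C)=O)cc2)N1`: 18000 nM

Compound 3 stands level with compound 1, within the scatter: a 1.1-fold lower number from compound 1 to compound 3 (0.03 log units; within the scatter). Its gap to compound 2 lies beyond the scatter: an at least 3.3-fold lower number from compound 2 to compound 3 (0.52 log units; beyond the scatter). The remaining step, an at least 3.1-fold higher number from compound 1 to compound 2 (0.49 log units; beyond the scatter), is of similar size. Both steps involving compound 2 are bounded on one side only: the limit of > 60000 nM in this assay, at which 1 of the 3 values shown sits.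

The next compound is compound 4 `CCCCCCCCC/C=C\CCCCCCCNC(=O)[C@@H]1CSC(c2ccc(NC(C)=O)cc2)N1`, which differs from compound 3 in double-bond geometry alone: the two compounds have the same atoms and bonds; at least one stereo element is drawn with a configuration in one of them and without one in the other: 1 of 3 stereo elements differ; a double bond is drawn E in compound 3 and Z in compound 4. Among the compounds with values here, no measured step isolates that geometry. The nearest guide is an at least 3.3-fold lower number from compound 2 to compound 3 (0.52 log units; beyond the scatter), where the chain of compound 3 carries a double bond and that of compound 2 does not, so changes in this chain can matter in this assay. That step gives no direction for the present change, so a shift within the scatter is the working expectation. The expected step is a 1.1-fold higher number from compound 3 to compound 4 (0.05 log units; within the scatter). For compound 4 the estimated value is 20000 nM, with an expected range from 8000 nM to 50000 nM.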

Compound 4, half-maximal inhibitory concentration: 10600 nM
Beside the measured number, compound 4's estimate is 1.9-fold (0.28 log units) above it; measured number inside the range.
By their numbers in this assay, from the lowest: compounds 4, 3 and 1 (each within the scatter of the next). At a limit, above all of these: compound 2.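

In this assay, exchanging the E double bond for the Z double bond gives a 1.7-fold lower number from compound 3 to compound 4 (0.23 log units; within the scatter), so double-bond geometry at this position shows no effect beyond the scatter, with one caveat on the drawing: the fact that one of compounds 3 and 4 is drawn with a defined configuration and the other without, at the place where they differ. The chain with the Z double bond also stays within the scatter of the shorter saturated chain, at a 1.8-fold lower number from compound 1 to compound 4 (0.26 log units; within the scatter). Beyond the scatter stands an at least 5.6-fold lower number from compound 2 to compound 4 (0.75 log units; beyond the scatter), a step bounded on one side only: the limit of > 60000 nM in this assay, at which 1 of the 4 values shown sits.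

Still open, from the compounds shown here alone, is whether a double bond elsewhere along the chain would behave as these two geometries do. The compounds shown also leave open whether a longer chain carrying a double bond, or a chain bearing an amine or a carboxylic acid, would shift the number in this assay.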